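The source may hold more compounds than are shown below. What is called first, only, known or untested is meant among the compounds shown, and "the series" means these compounds.

Of the compounds shown here, two have been measured in a functional assay on SW480 cells (Homo sapiens) for inhibition, read by luminescence and resazurin assay, with a stated time of 3 days; on this read-out lower numbers stand for stronger inhibition and higher numbers for weaker inhibition. Compound 1 `CNc1nc(NCc2ccc(NC(=O)c3ccc(F)cc3)cc2)c2ccccc2n1` gives 2000 nM in this assay. Compound 2 `C=CCNc1nc(NCc2ccc(C(=O)Nc3ccc(F)cc3)cc2)c2cc(C)ccc2n1` gives 10000 nM in this assay, the higher of the two numbers, and the gap to compound 1 lies beyond the scatter of the assay; the two compounds differ in more than one place, so nothing more than the two values themselves can be read from that gap. Compound 3 `CCCNc1nc(NCc2ccc(C(=O)Nc3ccc(F)cc3)cc2)c2cc(C)ccc2n1` has not been measured. It differs from compound 2 by ethyl in place of vinyl on a saturated chain carbon bound to a nitrogen on an aromatic ring, a change that only removes the double bond of a short chain. Among the measured compounds shown here, the measured compounds offer no step that isolates this change. Compound 3 is therefore expected to stay close to compound 2, with a step of a 1.3-fold lower number from compound 2 to compound 3 (0.10 log units; within the scatter) that should fall within the usual scatter. The estimate for compound 3 in this assay is 8000 nM, with a range from 3000 nM to 20000 nM.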

Compound 3, half-maximal inhibitory concentration: 1300 nM
Compound 3: the middle estimate sits 6.2-fold (0.79 log units) above what was measured; measured number below the stated range.
By their numbers in this assay, from the lowest: compounds 3 and 1 (each within the scatter of the next); then compound 2.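

In this assay, among the compounds shown here, the change from allylamino to propylamino goes with a 7.7-fold lower number from compound 2 to compound 3 (0.89 log units; beyond the scatter), the only comparison here in which a single place differs. The heavy-atom count of the group stays the same and the double bond outside the aromatic rings is gone, so the read-out at this position on the chain responds to that one double bond alone, which the earlier pair of compounds could not show. Nothing available here accounts for the size of this step.

For the compounds shown here, only this one pair carries the change, so it remains open whether the same step would appear on a different core or with other groups elsewhere on the molecule. Also open, from the compounds shown here alone, is how a longer chain such as butyl, a branched chain such as isopropyl, or a terminal amine on the chain would compare with propyl at this place.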